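Amides and acids on two pyridine-linked cores

The source may hold more compounds than are shown below. What is called first, only, known or untested is meant among the compounds shown, and "the series" means these compounds.

Compound 1 `Cn1ncc2cc(-c3cnccc3/C=C/C(=O)O)ccc21` in a functional assay on MCF7 cells (Homo sapiens) for inhibition, read by sulforhodamine B assay, with a stated time of 72 h; on this read-out higher numbers stand for weaker inhibition of growth and lower numbers for stronger inhibition of growth: > 10000 nM
Compound 2 `CNC(=O)CCc1ccncc1-c1ccc2ccccc2c1` in this assay: > 10000 nM
Compound 3 `O=C(O)CCc1ccncc1-c1ccc2ccccc2c1` in this assay: > 10000 nM

Each of these three values is a limit of the assay rather than a number. Compound 3 gives a limit in this assay, and compound 2 gives a limit in this assay, so the step that the two limits leave unreadable from compound 3 to compound 2, which is methylamino in place of hydroxy on a carbonyl carbon, cannot be read in size. The core of compound 1 and the core of compound 3 differ, but that difference is not broken down here.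

Compound 4 `CNC(=O)/C=C/c1ccncc1-c1ccc2c(cnn2C)c1` has not yet been measured. It arises from compound 1 by methylamino in place of hydroxy on a carbonyl carbon. The place differs from that of the step from compound 3 to compound 2, where the carbonyl carbon's other neighbour is a saturated chain carbon rather than a double-bonded chain carbon, so the two are the same kind of change but not the same. Since compound 1 and all three measured values sit at the limit of > 10000 nM in this assay, at which 3 of the 3 values shown sit, the expected step that the limit leaves unreadable from compound 1 to compound 4 in this assay is estimated to leave compound 4 at that limit too. Compound 4 is estimated at 20000 nM, with an expected range of 8000 nM to 60000 nM.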

Compound 4, concentration for 50% growth inhibition: > 10000 nM
Compound 4: only a limit was reported (the forecaster's own chance of this, stated with the estimate: 85%); the middle value lies beyond the limit too.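

Compound 1 and compound 4 each give only a limit in this assay, so no size can be read for the step between them, methylamino in place of hydroxy on a carbonyl carbon: the limit of > 10000 nM in this assay, at which 4 of the 4 values shown sit.

The compounds shown leave open how large this change is on either core, and whether any of them inhibits growth in this assay at all.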